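The compounds below may be only part of what the source reports. "The series", "measured", "known", "first", "only" and "open" are said of these compounds alone.

Of the compounds shown here, three of a shared core have been measured in a functional assay on PANC-1 cells (Homo sapiens) for inhibition, read by MTT assay, with a stated time of 24 h, tested at 10 uM; a lower number here means less inhibition, a higher number more inhibition at the concentration tested (going by the name of the read-out). Compound 1 `CC(C)=CCOc1cc(=O)n(CCCO)c2c1CC(CC=C(C)C)C(C)(C)C2` gives 20.7%, compound 2 `CC(C)=CCC/C(C)=C/COc1cc(=O)n(CCCO)c2c1CC(CC=C(C)C)C(C)(C)C2` gives 10.6%, and compound 3 `CC(C)=CCC1Cc2c(OCCCNS(=O)(=O)c3ccc(Cl)cc3)cc(=O)n(CCCO)c2CC1(C)C` gives 24.7%. Compound 3 thus shows the highest of the three numbers, although compound 1 stands within the usual scatter of it, while compound 2 lies beyond the scatter and lower. Going by the values given here, the only single-point step among the measured compounds is a number 10.1 percentage points lower from compound 1 to compound 2 (beyond the scatter); it concerns a different part of the molecule from the one changed next and therefore says nothing direct about the step now considered.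

Compound 4 `CC(C)=CCC1Cc2c(OCCCNC(=O)c3ccc([N+](=O)[O-])cc3)cc(=O)n(CCCO)c2CC1(C)C` differs from compound 3 in one place: (4-nitrophenyl)carbonyl in place of (4-chlorophenyl)sulfonyl on an amine nitrogen. Among the compounds with values here, no measured pair shows a change at this amine nitrogen, so there is no step of known size to lean on. Without such a guide, the expectation is that compound 4 stays near compound 3, with a step of a number 1.7 percentage points lower from compound 3 to compound 4 (within the scatter) that does not go beyond the scatter, and with a wide range to reflect the lack of a comparable step. Compound 4 is therefore estimated at 23% in this assay, expected to fall between 8% and 40%.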

Compound 4, a percentage reported as inhibition, at one concentration (the size of the read-out at that concentration, not a potency): 49.9%
The estimate for compound 4 lay 26.9 percentage points below the measured number; measured number outside the range, above it.
By their numbers in this assay, from the lowest: compound 2; then compounds 1 and 3 (each within the scatter of the next); then compound 4.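

In this assay, going by these compounds alone, replacing (4-chlorophenyl)sulfonyl with (4-nitrophenyl)carbonyl on this amine nitrogen gives a number 25.2 percentage points higher from compound 3 to compound 4 (beyond the scatter), the first sign that the number responds to what this nitrogen carries, since no earlier pair changed anything at this place. The exchange alters two things at once, the sulfonyl link becoming a carbonyl link and the chlorine on the aromatic ring giving way to a nitro group, so the step belongs to the whole swap and cannot be credited to either part alone. No measurement available here bears on why the number rises at this position.

The compounds shown leave open which part carries the step, a question that the crossed pair of (4-chlorophenyl)carbonyl and (4-nitrophenyl)sulfonyl on the same nitrogen could settle. They also leave open whether the aromatic ring needs any such group at all, as an unsubstituted phenylcarbonyl would show, and how a 4-aminophenyl or 4-carboxyphenyl carbonyl group would compare with the nitro group.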